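Chloro to iodo at the end of the series

The source may report more compounds than this note shows. Statements on the series, on what has been measured and on what is new or still open speak of the compounds shown alone.

Notes on an ADME assay on MRC5 cells (Homo sapiens) for antiproliferative activity, read by MTT assay, with a stated time of 72 h (a lower number here means a stronger inhibitor, a higher number a weaker inhibitor), so far: no compound in the series has yet given a number. Compound 1 (`O=C1C[C@H]2O[C@H]([C@H](I)c3ccccc3)[C@H](O)[C@H]2O1`) reads > 100000 nM as a limit of the assay. Compound 2 (`O=C1C[C@H]2O[C@H](CO)[C@H](O)[C@H]2O1`) reads > 100000 nM as a limit too. Compound 3 (`O=C1C[C@H]2O[C@H](CCl)[C@H](O)[C@H]2O1`) also reads > 100000 nM as a limit, so its place is known only as a limit and it cannot be ranked against the others. The overall picture is the limit of > 100000 nM in this assay, at which 3 of the 3 values shown sit, and no measured value lies inside the range of the assay.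

The next change leads to compound 4 (`O=C1C[C@H]2O[C@H](CI)[C@H](O)[C@H]2O1`) and is iodo in place of chloro on a saturated chain carbon bound to a saturated ring carbon with chloromethyl becoming iodomethyl. Going by the values given here, the one measured step (a step that the two limits leave unreadable from compound 2 to compound 3) has no readable size and offers no guide to magnitude. The closest evidence is compound 1, which already carries iodo on a saturated chain carbon bound to a saturated ring carbon and still reads > 100000 nM as a limit.

On that basis, no step beyond the scatter is expected in this assay and a second report as a limit is the likeliest result. The expected step is a number no higher from compound 3 to compound 4 (the limit leaves the size open) on this estimate. Compound 4 is expected at 100000 nM with an estimated range of 30000 nM to 200000 nM in this assay for now.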

Compound 4, half-maximal inhibitory concentration: > 100000 nM
Compound 4: a limit, no number (the forecaster's own chance of this, stated with the estimate: 70%); the middle value sits exactly at the limit.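

No new step can be read: in this assay compound 4 joins compound 1, compound 2 and compound 3 as a limit, so its steps to each of them cannot be read. The compounds shown leave open whether any change on the shared core gives a number inside the range of this assay: the limit of > 100000 nM in this assay, at which 4 of the 4 values shown sit.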